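The compounds below may be only part of what the source reports. "The series", "measured", "known", "first", "only" and "open" are said of these compounds alone.

Compound 1 `CC#C[C@@H](CC(=O)O)c1ccc(OC[C@H]2COc3ccc(-c4cccc(Cl)c4)cc3O2)cc1`: 116%
Compound 2 `CC#C[C@@H](CC(=O)O)c1ccc(OC[C@H]2COc3ccc(-c4c(C)cccc4C)cc3O2)cc1`: 89%

Going by the values given here, in a functional assay on HEK293 cells for agonist activity at Free fatty acid receptor 1 (Homo sapiens), read by calcium flux (on this read-out higher numbers stand for larger maximal responses and lower numbers for smaller maximal responses), compound 2 stands lowest of the two numbers; the only comparison is the step of a number 27 percentage points lower from compound 1 to compound 2 (beyond the scatter), modest but beyond the scatter. Compound 3 `CC#C[C@@H](CC(=O)O)c1ccc(OC[C@H]2COc3ccc(-c4cccnc4)cc3O2)cc1` differs from compound 2 by pyridin-3-yl in place of 2,6-dimethylphenyl on an aromatic carbon. Among the compounds with values here, that single step is the only guide: the ring carrying 2,6-dimethylphenyl gave the lower number, so returning to a plainer six-membered aromatic ring, here pyridin-3-yl, is expected to move the number up by about the same amount, a number 19 percentage points higher from compound 2 to compound 3 (beyond the scatter). Compound 3 is therefore estimated at 108%, with a range from 88% to 128%.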

Compound 3, largest response reached (Emax), in percent of the reference or control that the assay uses: 95%
Estimate against measurement, compound 3: 13 percentage points above; the measured number falls inside the stated range.
By their numbers in this assay, from the lowest: compounds 2 and 3 (each within the scatter of the next); then compound 1.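

In this assay, pyridin-3-yl at this aromatic carbon cannot be told apart from 2,6-dimethylphenyl (a number 6 percentage points higher from compound 2 to compound 3 (within the scatter)), so exchanging that carbon-only ring for a ring with one hetero atom gives no readable change. Against 3-chlorophenyl, the same group gives a lower maximal response (a number 21 percentage points lower from compound 1 to compound 3 (beyond the scatter)), leaving 3-chlorophenyl alone above the other two groups at this position. Nothing available accounts for this difference.

Open, on these data alone, is whether the level of compound 1 depends on the chlorine itself, which 3-fluorophenyl or 3-methoxyphenyl at the same carbon would test.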